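This account rests on a few compounds, and the source may have more. Where it says the series, first, only, none or still open, it means among the compounds named here.

Going by the values given here, in a functional assay on the whole organism (strain Sprague-Dawley) for inhibition, with Rattus norvegicus as the target, with a stated time of 10 min (a higher number here means that more compound is needed for the effect, a lower number that less compound is needed), compound 2 `CC(C)COc1ccccc1-c1ncc(C(=O)O)c(=O)[nH]1` gives 0.5 mg/kg as the only true number so far. Compound 1 `O=C(O)c1cnc(-c2ccccc2[N+](=O)[O-])[nH]c1=O` gives > 50 mg/kg and this is a limit of the assay. The next structure is compound 3 `C=CCOc1ccccc1-c1ncc(C(=O)O)c(=O)[nH]1` and its change from compound 2 is this: vinyl in place of isopropyl on a saturated chain carbon bound to an oxygen on an aromatic ring so that isobutoxy becomes allyloxy. Among the compounds with values here, the only measured step bears on this loosely: with an at least 100-fold lower number from compound 1 to compound 2 (2.00 log units; beyond the scatter) a large change came from exchanging the whole group, nitro for isobutoxy on an aromatic carbon, whereas here only the end of the chain is altered. Within the data shown here, no measured step covers such a change alone. A shift within the scatter is therefore expected in this assay with no firm direction. The expected step is a 1.6-fold higher number from compound 2 to compound 3 (0.20 log units; within the scatter) as an estimate. Compound 3 is estimated at 0.8 mg/kg with an expected range from 0.2 mg/kg to 3 mg/kg in this measurement.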

Compound 3, dose for 50% inhibition: 0.5 mg/kg
The estimate for compound 3 lay 1.6-fold (0.20 log units) above the measured number; low and high end bracket the measured number.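

In this assay, vinyl in place of isopropyl on a saturated chain carbon bound to an oxygen on an aromatic ring gives a clear reading (here no change at the digits printed from compound 2 to compound 3 (within the scatter)), so at this chain end a double bond with one carbon fewer serves as well as the branched group. Allyloxy in place of nitro also gives a large step (an at least 100-fold lower number from compound 1 to compound 3 (2.00 log units; beyond the scatter)), which shows that the result for isobutoxy is not confined to that one chain. Compound 1 stands at a limit of the assay, so this step gives a bound and not a size: the limit of > 50 mg/kg in this assay, at which 1 of the 3 values shown sits.

The compounds shown leave open whether the oxygen itself is needed, which an amine in its place would test. They also leave open how far the chain can grow, which a longer chain or a benzyl group would test.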